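The source may report more compounds than this note shows. Statements on the series, on what has been measured and on what is new or still open speak of the compounds shown alone.

Measured so far in a functional assay on HOS-TE85 cells (Homo sapiens) for inhibition, read by CCK-8 assay, with a stated time of 72 h (a higher number here means a weaker inhibitor, a lower number a stronger inhibitor), for this series:
- compound 1 `COc1ccc(C)cc1N1C(=O)CSC1c1cccc(C(=O)NCCCCc2ccccc2)c1` gives 300 nM
- compound 2 `O=C(NCCCCc1ccccc1)c1cccc(C2SCC(=O)N2c2ccc(-c3ccccc3)cc2)c1` gives > 1000 nM (a limit of the assay, not a number)
- compound 3 `O=C(NCCCCc1ccccc1)c1cccc(C2SCC(=O)N2c2cccc(F)c2)c1` gives 32.4 nM

Compound 3 holds the lowest of the two numbers, and compound 2 reports only a limit. Next is compound 4 `COc1ccc(N2C(=O)CSC2c2cccc(C(=O)NCCCCc3ccccc3)c2)c(OC)c1` which differs from compound 3 in one place, on an amide-type nitrogen in a ring, where 2,4-dimethoxyphenyl replaces 3-fluorophenyl (2,4-dimethoxyphenyl in place of 3-fluorophenyl on an amide-type nitrogen in a ring). All three measured steps fall at this same place and all lie beyond the scatter. The step of a 9.3-fold lower number from compound 1 to compound 3 (0.97 log units; beyond the scatter) is modest, the step of an at least 3.3-fold higher number from compound 1 to compound 2 (0.52 log units; beyond the scatter) is at least modest, and the step of an at least 30-fold lower number from compound 2 to compound 3 (1.48 log units; beyond the scatter) is large. Of the groups already measured, the 2-methoxy-5-methylphenyl of compound 1 is the closest by name to the incoming group, so the first of these steps, read in reverse, is the best guide. In this assay a rise of similar size is therefore expected, with compound 1 at 300 nM as the anchor. The estimate means a 7.7-fold higher number from compound 3 to compound 4 (0.89 log units; beyond the scatter) as an expected rise beyond the scatter. Compound 4 is estimated at 250 nM (expected range 70 nM to 900 nM).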

Compound 4, half-maximal inhibitory concentration: 90.4 nM
Compound 4: the middle estimate sits 2.8-fold (0.44 log units) above what was measured; the measured number falls inside the stated range.
By their numbers in this assay, from the lowest: compound 3; then compound 4; then compound 1. At a limit, above all of these: compound 2.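

In this assay, a 3.3-fold lower number from compound 1 to compound 4 (0.52 log units; beyond the scatter), so two aryl groups that both carry a methoxy group are not interchangeable on this amide-type nitrogen, and the presence of a methoxy group alone does not set the number. With a 2.8-fold higher number from compound 3 to compound 4 (0.45 log units; beyond the scatter), the 3-fluorophenyl keeps the lower number, although the step is modest and the entering 2,4-dimethoxyphenyl has 10 heavy atoms and 2 hydrogen-bond acceptors against 7 and 0 for the group it replaces. The third step, an at least 11-fold lower number from compound 2 to compound 4 (1.04 log units; beyond the scatter), is a bound and not a size, since it starts from a limit: the limit of > 1000 nM in this assay, at which 1 of the 4 values shown sits.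

The four groups shown differ in several features at once, so the separate contributions of the fluorine, each methoxy group, the methyl group and the added phenyl ring remain unresolved, and a matched set such as 3-chlorophenyl, 3-methoxyphenyl and 4-methoxyphenyl would separate them more directly. Also open, as far as these compounds go, is whether a pyridine ring on this nitrogen, or a carboxylic acid or an amine on the aryl ring, would be tolerated, and whether the order seen here holds with a shorter chain on the amide of the shared core.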